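The compounds below may be only part of what the source reports. "The series", "measured", "known", "first", "only" and "open" are said of these compounds alone.

Compound 1 `O=C(Nc1ccc(Cl)c(-c2nnc3c(Cl)cccn23)c1)c1ccc(F)cc1Cl` — in a functional assay on MCF7 cells (Homo sapiens) for antiproliferative activity, read by MTT assay, with a stated time of 72 h (on this read-out higher numbers stand for weaker inhibition and lower numbers for stronger inhibition), compound 1 gives > 100000 nM, a limit of the assay.
Compound 2 `Cc1nc(C(=O)Nc2ccc(Cl)c(-c3nnc4c(Cl)cccn34)c2)cs1` — compound 2 gives > 100000 nM, again a limit of the assay.
Compound 3 `CS(=O)(=O)c1ccc(C(=O)Nc2ccc(Cl)c(-c3nnc4c(Cl)cccn34)c2)cc1` — compound 3 gives 94200 nM.

Compound 1 thus stands at the limit, where most of the group sits (the limit of > 100000 nM in this assay, at which 2 of the 3 values shown sit). Swapping the group on the carbonyl carbon gave a step that the two limits leave unreadable from compound 1 to compound 2 and an at least 1.0-fold lower number from compound 1 to compound 3 (0.02 log units; that floor lies within the scatter), and between the two replacements an at least 1.0-fold lower number from compound 2 to compound 3 (0.02 log units; that floor lies within the scatter); nothing moved beyond the scatter. Compound 4 `O=C(Nc1ccc(Cl)c(-c2nnc3c(Cl)cccn23)c1)c1ccccc1` makes the same kind of swap: phenyl in place of 2-chloro-4-fluorophenyl on a carbonyl carbon. With the comparable changes staying at or near the limit, no step beyond the scatter is expected, so a number no higher from compound 1 to compound 4 (the limit leaves the size open) is the estimate. Compound 4 is expected at 100000 nM, within 50000 nM to 300000 nM, most likely reported only as a limit.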

Compound 4, half-maximal inhibitory concentration: > 100000 nM
Compound 4 ended at the assay's limit; the forecaster's own chance of this, stated with the estimate: 75%; the middle value lies on the limit itself.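

Even the plain phenyl, carrying neither the chlorine nor the fluorine of compound 1, leaves the activity on this carbonyl carbon unchanged as far as can be seen, and the steps between two limits cannot be read. Replacing methylsulfonyl with hydrogen on the aromatic carbon gives an at least 1.0-fold higher number from compound 3 to compound 4 (0.02 log units; that floor lies within the scatter), so that group too has no effect beyond the scatter in this assay. The series now clusters at one end of the scale: the limit of > 100000 nM in this assay, at which 3 of the 4 values shown sit.

Still open, from the compounds shown here alone, is whether an amine or a carboxylic acid on the phenyl ring would bring a value clear of the limit. The same goes for a longer chain on the carbonyl carbon.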